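Swapping a hydroxyethyl tail for a bromophenyl group

The source may report more compounds than this note shows. Statements on the series, on what has been measured and on what is new or still open speak of the compounds shown alone.

Measured so far in a functional assay on HeLa cells (Homo sapiens) for antiproliferative activity, read by MTT assay, with a stated time of 72 h; a higher number here means a weaker inhibitor, a lower number a stronger inhibitor:
compound 1 `O=C1O[C@H]([C@@H](O)Cn2cc(CNS(=O)(=O)c3ccc(Cl)cc3F)nn2)C(OCc2ccccc2)=C1OCc1ccccc1`: 20700 nM
compound 2 `O=C1O[C@H]([C@@H](O)Cn2cc(CCO)nn2)C(OCc2ccccc2)=C1OCc1ccccc1`: 68800 nM
compound 3 `CCCCCc1ccc(-c2cn(C/C=C3\OC(=O)C(OCc4ccccc4)=C3OCc3ccccc3)nn2)cc1`: > 100000 nM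

Compound 3 gives only a limit, (the limit of > 100000 nM in this assay, at which 1 of the 3 values shown sits), not a number. Among the two numbers, compound 2 stands at the highest, and its nearest neighbour is compound 1, the step of a 3.3-fold higher number from compound 1 to compound 2 (0.52 log units; beyond the scatter) being modest but beyond the scatter. Compound 4 `O=C1O[C@H]([C@@H](O)Cn2cc(-c3ccc(Br)cc3)nn2)C(OCc2ccccc2)=C1OCc1ccccc1` has not been measured. It differs from compound 2 in one place: 4-bromophenyl in place of 2-hydroxyethyl on an aromatic carbon. Among the compounds with values here, only the step from compound 1 to compound 2 bears on this, and it shows that replacing the small hydroxyl-bearing group with a larger aromatic one strengthened inhibition modestly; compound 3, which also carries an aryl on the five-membered ring but on a different core, gives only a limit. Compound 4 is therefore expected to sit modestly below compound 2, a step of a 1.5-fold lower number from compound 2 to compound 4 (0.18 log units; within the scatter), with an estimate of 45000 nM, between 15000 nM and 100000 nM.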

Compound 4, half-maximal inhibitory concentration: 3910 nM
For compound 4 the middle estimate is 12-fold (1.06 log units) above the measured one; measured number below the stated range.
By their numbers in this assay, from the lowest: compound 4; then compound 1; then compound 2. At a limit, above all of these: compound 3.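

In this assay, 4-bromophenyl in place of 2-hydroxyethyl brings an 18-fold lower number from compound 2 to compound 4 (1.25 log units; beyond the scatter) as a large step, so the group on this aromatic carbon of the five-membered ring can strongly change the result. The earlier step at this carbon, a 3.3-fold higher number from compound 1 to compound 2 (0.52 log units; beyond the scatter), was modest, and neither of its compounds carries an aromatic ring there. Nothing measured here explains the gain.

Going by these compounds, whether the bromine matters, or a plain phenyl ring would do as well, stays open. So does the effect of an amine or a carboxylic acid on that ring.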